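This account rests on a few compounds, and the source may have more. Where it says the series, first, only, none or still open, it means among the compounds named here.

In an assay on isolated protein for inhibition of protein kinase C theta type (Homo sapiens), read by HTRF (a lower number here means a stronger inhibitor, a higher number a weaker inhibitor), compound 2 `CO[C@@H]1[C@H](N(C)C=O)C[C@H]2O[C@]1(C)n1c3ccccc3c3c4c(c5c6ccccc6n2c5c31)C(=O)NC4` gives 250 nM, the only result among the three measured compounds that is reported as a number rather than a limit. Compound 1 `CO[C@@H]1C(=O)C[C@H]2O[C@]1(C)n1c3ccccc3c3c4c(c5c6ccccc6n2c5c31)C(=O)NC4` returns only a limit of the assay, > 2500 nM. Compound 3 `CO[C@@H]1[C@@H](O)[C@@H](O)[C@H]2O[C@]1(C)n1c3ccccc3c3c4c(c5c6ccccc6n2c5c31)C(=O)N[C@@H]4O` likewise returns only a limit of the assay, > 2500 nM. Within the data shown here, two of the three results therefore sit at the limit of > 2500 nM in this assay, at which 2 of the 3 values shown sit, and no two measured compounds differ in a single place, so no measured step is available to guide the next change. Compound 4 `CO[C@@H]1[C@H](NC(C)=O)C[C@H]2O[C@]1(C)n1c3ccccc3c3c4c(c5c6ccccc6n2c5c31)C(=O)NC4` has not yet been measured in this assay. It differs from compound 2 by acetamido in place of formyl(methyl)amino on a saturated ring carbon. The two compounds have the same atoms joined differently, and the rearrangement is modest in size. The step of a 1.4-fold higher number from compound 2 to compound 4 (0.15 log units; within the scatter) is expected to stay within, or only just beyond, the usual scatter, with a slight lean toward weaker inhibition. For compound 4 the estimate is 350 nM, with a likely range from 100 nM to 1200 nM.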

Compound 4, half-maximal inhibitory concentration: 38 nM
Beside the measured number, compound 4's estimate is 9.2-fold (0.96 log units) above it; measured number below the stated range.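

In this assay, the step to acetamido from formyl(methyl)amino on this saturated ring carbon is a 6.6-fold lower number from compound 2 to compound 4 (0.82 log units; beyond the scatter), so the position responds clearly to a rearrangement of the same atoms. The entering acetamido carries a hydrogen-bond donor that the leaving formyl(methyl)amino lacks, and this is the one counted difference between the two groups, although a single pair cannot show that it accounts for the step. The data shown offer no measured reason for the step.

As far as these compounds go, it remains open how this position would respond to a free amine, a longer chain such as propionamido, or a methanesulfonamido group. From the compounds shown here alone, it is also open whether the step would hold on the other stereoisomer at this carbon.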